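The source may report more compounds than this note shows. Statements on the series, on what has been measured and on what is new or still open speak of the compounds shown alone.

In a functional assay on MDA-MB-435 cells (Homo sapiens) for cytotoxicity, read by MTT assay, with a stated time of 72 h (on this read-out lower numbers stand for stronger inhibition and higher numbers for weaker inhibition), compound 3 `O=C(NCc1ccc(F)cc1)c1nc(Br)c2cccnc2c1NCCO` gives no true number, only a limit: compound 3 reads > 20000 nM. Compound 1 `O=C(NCc1ccc(F)cc1)c1nc(Br)c2cccnc2c1NCc1ccc(F)cc1` is also a limit, at > 20000 nM. Together they make up (the limit of > 20000 nM in this assay, at which 2 of the 3 values shown sit). Only compound 2 `CN(C)CCCNc1c(C(=O)NCc2ccc(F)cc2)nc(Br)c2cccnc12` gives a measured number, with compound 2 at 7000 nM.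

Compound 4 `C[C@H](Nc1c(C(=O)NCc2ccc(F)cc2)nc(Br)c2cccnc12)c1ccccc1` has 1-phenylethyl in place of 2-hydroxyethyl on a nitrogen on an aromatic ring. The two readable steps are an at least 2.8-fold lower number from compound 1 to compound 2 (0.45 log units; beyond the scatter) and an at least 2.8-fold higher number from compound 2 to compound 3 (0.45 log units; beyond the scatter). Both turn on the dimethylamino group of compound 2, which compound 4 lacks, so neither offers a direct guide. Compound 1 resembles compound 4 more closely, as both carry an aromatic ring on the group at that nitrogen, yet it reaches only the limit. The link to it is a step that the two limits leave unreadable from compound 1 to compound 3.

No clear gain is therefore expected, and the estimated change is a number no higher from compound 3 to compound 4 (the limit leaves the size open). For compound 4, the expected value is about 20000 nM, within an estimated range of 8000 nM to 50000 nM.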

Compound 4, half-maximal inhibitory concentration: > 20000 nM
Compound 4 was reported as a limit; the forecaster's own chance of this, stated with the estimate: 65%; the middle value sits exactly at the limit.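

In this assay, putting 1-phenylethyl in place of 3-(dimethylamino)propyl on the nitrogen gives an at least 2.8-fold higher number from compound 2 to compound 4 (0.45 log units; beyond the scatter). The steps to compound 4 from compound 1 and from compound 3 cannot be read, and most of this small set now stops at one assay limit: the limit of > 20000 nM in this assay, at which 3 of the 4 values shown sit. Across the four groups tried on this nitrogen, only the 3-(dimethylamino)propyl of compound 2 gives a measured number, while a second group carrying an aromatic ring, the 1-phenylethyl of compound 4, joins compound 1 and compound 3 at the limit.

As far as these compounds go, how compound 1, compound 3 and compound 4 rank among themselves stays unknown, as does any effect of the defined stereocentre in compound 4. From the compounds shown here alone, it also remains open whether a longer chain ending in dimethylamino, or a chain ending in a piperidine ring, would match or improve on compound 2.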